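A few compounds are considered here, and "the series" means these few. Any claim that something is new, unique, unknown or untested is made for them only; others in the source may bear on it.

Values in an ADME assay on WI-38 cells (Homo sapiens) for cytotoxicity, read by MTT assay, with a stated time of 72 h (on this read-out lower numbers stand for stronger inhibition and higher numbers for weaker inhibition), for the compounds measured so far
- Compound 1 `O=C(CCc1cccc2c1B(O)OC2)Nc1ccc(F)cc1` gives 12000 nM as a number
- Compound 2 `COc1ccc(NC(=O)CCc2cccc3c2B(O)OC3)cc1` gives > 100000 nM as a limit
- Compound 3 `CC(C)(C)OC(=O)Nc1ccc(NC(=O)CCc2cccc3c2B(O)OC3)cc1` gives > 100000 nM as a limit

Compound 3 has only a limit (> 100000 nM) and no number. Compound 4 `O=C(CCc1cccc2c1B(O)OC2)Nc1ccc(-c2ccccc2)cc1` differs from it by phenyl in place of (tert-butoxycarbonyl)amino on an aromatic carbon on the shared core. Two measured steps replace the fluoro of compound 1, and both raise the number. One is an at least 8.3-fold higher number from compound 1 to compound 2 (0.92 log units; beyond the scatter) and the other is an at least 8.3-fold higher number from compound 1 to compound 3 (0.92 log units; beyond the scatter) in the same assay. The third is a step that the two limits leave unreadable from compound 2 to compound 3 and adds nothing. Within the data shown here, no measured compound carries this phenyl. Among the measured compounds shown here, compound 1 at 12000 nM is the only compound with a number, so a modest downward move in this assay is expected, with wide uncertainty. The expected step is an at least 2.8-fold lower number from compound 3 to compound 4 (0.45 log units; beyond the scatter) on this estimate. Compound 4 is estimated at 35000 nM with an expected range from 9000 nM to 100000 nM overall.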

Compound 4, half-maximal inhibitory concentration: 32000 nM
The estimate for compound 4 lay 1.1-fold (0.04 log units) above the measured number; the range from low to high includes it.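

In this assay phenyl at this position gives a number where methoxy and (tert-butoxycarbonyl)amino give only limits of the assay, with an at least 3.1-fold lower number from compound 3 to compound 4 (0.49 log units; beyond the scatter) and an at least 3.1-fold lower number from compound 2 to compound 4 (0.49 log units; beyond the scatter) on replacing those groups. Phenyl does not match fluoro, though: a 2.7-fold higher number from compound 1 to compound 4 (0.43 log units; beyond the scatter) still separates them. The two steps from the limits give only a minimum size, because they start from limits of the assay: the limit of > 100000 nM in this assay, at which 2 of the 4 values shown sit.

Going by these compounds, whether an amine or a carboxylic acid at this position would give a number closer to that of fluoro stays open. So does the effect of a longer chain in place of phenyl on the shared core.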